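The compounds below may be only part of what the source reports. "The series", "measured", "known", "first", "only" and "open" are said of these compounds alone.

Of the compounds shown here, three of one series have been measured in an ADME assay on Vero cells (Chlorocebus sabaeus) for cytotoxicity, read by MTT assay, with a stated time of 72 h; a higher number here means that more compound is tolerated, a lower number that less compound is tolerated. Compound 1 `COc1ccc(CN(Cc2cc3ccccc3nc2OC)CC(O)CN2CCCC2)cc1` gives in this assay a half-maximal cytotoxic concentration of 664000 nM. Compound 2 `COc1nc2ccccc2cc1CN(Cc1ccc(Cl)cc1)CC(O)CN1CCCC1` gives 898000 nM in this assay. Compound 3 `CCN(CC)CC(O)CN(Cc1ccc(Cl)cc1)Cc1cc2ccccc2nc1OC` gives 808000 nM in this assay. The difference between compound 2 and compound 1 is methoxy in place of chloro on an aromatic carbon, and it made the step of a 1.4-fold lower number from compound 2 to compound 1 (0.13 log units; within the scatter). Compound 2 and compound 3 differ in their cores by diethylamino in place of pyrrolidin-1-yl on a saturated chain carbon, two bonds along the chain from an oxygen on a saturated carbon, which made the step of a 1.1-fold lower number from compound 2 to compound 3 (0.05 log units; within the scatter). All three numbers lie within the usual scatter of one another, so no order among them is claimed.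

Compound 4 `CCN(CC)CC(O)CN(Cc1ccc(OC)cc1)Cc1cc2ccccc2nc1OC` has not been measured in this assay. It differs from compound 3 by methoxy in place of chloro on an aromatic carbon, which is the same change that was made from compound 2 to compound 1, and it is made on the core of compound 3 rather than the core of compound 2. For compound 4 in this assay the expected step is a 1.3-fold lower number from compound 3 to compound 4 (0.13 log units; within the scatter), a step of about the size of the earlier one, because the same change on the core of compound 2 gave a 1.4-fold lower number from compound 2 to compound 1 (0.13 log units; within the scatter) and the cores differ only by diethylamino in place of pyrrolidin-1-yl on a saturated chain carbon, two bonds along the chain from an oxygen on a saturated carbon. The expected value for compound 4 in this assay is therefore 600000 nM, with an estimated range from 350000 nM to 1100000 nM.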

Compound 4, half-maximal cytotoxic concentration: 727000 nM
The estimate for compound 4 lay 1.2-fold (0.08 log units) below the measured number; the measured number falls inside the stated range.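

In this assay, methoxy in place of chloro on the core of compound 3 gave a 1.1-fold lower number from compound 3 to compound 4 (0.05 log units; within the scatter), and set beside the earlier step on the core of compound 2, the change reads alike on both cores: the same change on two cores in this assay, a 1.4-fold lower number (0.13 log units; within the scatter) from compound 2 to compound 1 and a 1.1-fold lower number (0.05 log units; within the scatter) from compound 3 to compound 4, 1.2-fold (0.09 log units) apart, within the scatter of two such steps. Diethylamino in place of pyrrolidin-1-yl, now read on the methoxy-bearing core, gave a 1.1-fold higher number from compound 1 to compound 4 (0.04 log units; within the scatter), and this change also reads alike on its two cores: the same change on two cores in this assay, a 1.1-fold lower number (0.05 log units; within the scatter) from compound 2 to compound 3 and a 1.1-fold higher number (0.04 log units; within the scatter) from compound 1 to compound 4, 1.2-fold (0.09 log units) apart, within the scatter of two such steps. Within the data shown here, all of these steps lie within the scatter, so the four compounds show only that neither change moved the number beyond the scatter on these cores; they do not show that either change has a real effect of its own that carries from one core to another, nor that the same would hold on any further core.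

The compounds shown leave open whether a different group in place of chloro and methoxy, such as a nitrile, a carboxylic acid or an amine, would give a step beyond the scatter in this assay. They also leave open what a morpholine or a piperidine would do in place of diethylamino and pyrrolidin-1-yl, and what a longer chain would do.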